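The compounds below may be only part of what the source reports. "The series", "measured", "known", "first", "only" and "open" are said of these compounds alone.

Compound 1 `O=C(/C=C/c1ccc2c(c1)B(O)OC2)c1cccnc1`, compound 2 `Cc1ccc(C(=O)/C=C/c2ccc3c(c2)B(O)OC3)cc1` and compound 3 `O=C(/C=C/c1ccc2c(c1)B(O)OC2)c1ccc(O)cc1` share one core and differ only in the group on the carbonyl carbon. In a toxicity assay on MCF-10A cells (Homo sapiens) for cytotoxicity, read by MTT assay, with a stated time of 48 h (a lower number here means a stronger inhibitor, a higher number a weaker inhibitor), compound 1 gives 34400 nM, compound 2 gives 8300 nM and compound 3 gives 24800 nM. Among these three numbers compound 3 stands second highest: the step of a 1.4-fold lower number from compound 1 to compound 3 (0.14 log units; within the scatter) stays within the scatter, whereas the step of a 3.0-fold higher number from compound 2 to compound 3 (0.48 log units; beyond the scatter) lies beyond it, as does the step of a 4.1-fold lower number from compound 1 to compound 2 (0.62 log units; beyond the scatter).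

Compound 4 `O=C(/C=C/c1ccc2c(c1)B(O)OC2)c1ccccc1O` is the next case. It differs from compound 3 by 2-hydroxyphenyl in place of 4-hydroxyphenyl on a carbonyl carbon. Among the measured compounds shown here, none of the measured steps moves a hydroxy group from one place on the phenyl ring to another; the steps that touch the hydroxyphenyl group, a 1.4-fold lower number from compound 1 to compound 3 (0.14 log units; within the scatter) and a 3.0-fold higher number from compound 2 to compound 3 (0.48 log units; beyond the scatter), exchange it for a different group altogether, and their sizes range from within the scatter to modest. For the measured compounds named here, there is therefore no measured step that speaks to this change, and the expectation is a step of no more than the scatter in either direction. On that basis compound 4 is expected to give 25000 nM in this assay, within a range of 10000 nM to 60000 nM, which means an expected step of a 1.0-fold higher number from compound 3 to compound 4 (0.00 log units; within the scatter).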

Compound 4, half-maximal inhibitory concentration: 53700 nM
Compound 4: the middle estimate sits 2.1-fold (0.33 log units) below what was measured; the range from low to high includes it.
By their numbers in this assay, from the lowest: compound 2; then compounds 3, 1 and 4 (each within the scatter of the next, the first and the last beyond it).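

In this assay, moving the hydroxy group on the phenyl ring is not a silent change: 2-hydroxyphenyl in place of 4-hydroxyphenyl on a carbonyl carbon gives (a 2.2-fold higher number from compound 3 to compound 4 (0.34 log units; beyond the scatter)) even though the two groups have the same atoms and the same donor and acceptor counts, so this position responds to the arrangement of the group as well as to its identity. Set against 4-methylphenyl, the same 2-hydroxyphenyl group gives (a 6.5-fold higher number from compound 2 to compound 4 (0.81 log units; beyond the scatter)), which widens the spread of numbers seen at this position, whereas set against pyridin-3-yl it gives (a 1.6-fold higher number from compound 1 to compound 4 (0.19 log units; within the scatter)), so that compound 1 and compound 4 cannot be told apart here. Nothing available explains why the place of the hydroxy group matters in these cells.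

As far as these compounds go, it remains open whether a methoxy group or an amine in place of the hydroxy group would show the same dependence on place on the phenyl ring. From the compounds shown here alone, it is also open whether a carboxylic acid on that ring would bring the number closer to that of compound 1 or to that of compound 2.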